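A few compounds are considered here, and "the series" means these few. Any claim that something is new, unique, unknown or untested is made for them only; others in the source may bear on it.

Compound 1 `COc1cc(-c2cc(/C=C/C(=O)c3ccc(N)cc3)[nH]n2)cc(OC)c1OC` and compound 2 `COc1ccc(-c2cc(/C=C/C(=O)c3ccc(OC)c(OC)c3)[nH]n2)cc1` share a core and were both examined in a functional assay on OVCAR-3 cells (Homo sapiens) for cytotoxicity, read by sulforhodamine B assay, with a stated time of 48 h, tested at 1 uM; on this read-out lower numbers stand for a stronger effect and higher numbers for a weaker effect at the one concentration tested. In this assay compound 1 gives 79%, the higher of the two numbers and thus the weaker effect at the single concentration used. Compound 2 gives 62% in this assay, a number lower by more than the usual scatter. The two compounds differ in several places at once, so this gap cannot be tied to any single change. Compound 3 `COc1cc(-c2cc(/C=C/C(=O)c3ccc(Cl)c(Cl)c3)[nH]n2)cc(OC)c1OC` has not yet been measured. It differs from compound 1 in one place: 3,4-dichlorophenyl in place of 4-aminophenyl on a carbonyl carbon. For the measured compounds named here, no measured pair isolates such a change, so its direction is open. A step of modest size, toward a stronger effect, is expected, partly because compound 2, which also carries no amine, gives 62%. For compound 3 a value of 68% is expected in this assay, between 45% and 92%. The expected step is a number 11 percentage points lower from compound 1 to compound 3 (beyond the scatter).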

Compound 3, a percentage reported as activity, at one concentration (the size of the read-out at that concentration, not a potency): 102%
The estimate for compound 3 lay 34 percentage points below the measured number, outside the stated range (above it).
By their numbers in this assay, from the lowest: compound 2; then compound 1; then compound 3.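

Swapping 4-aminophenyl for 3,4-dichlorophenyl on a carbonyl carbon is the first change here that can be read on its own, and in this assay it gives a number 23 percentage points higher from compound 1 to compound 3 (beyond the scatter), meaning a weaker effect at the one concentration tested. What sits at this position therefore matters, and removing the amine in this way does not bring a stronger effect; compound 2 differs from compound 3 in several places, so it cannot speak to this change. Nothing available explains why the number rises.

Because the amine leaves and the two chlorine atoms enter in a single step, the compounds shown cannot say which of these events accounts for the rise. A plain phenyl group on the same carbonyl carbon, with the rest of compound 1 kept, would help to separate the two.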